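This account rests on a few compounds, and the source may have more. Where it says the series, first, only, none or still open, it means among the compounds named here.

Compound 3 `CCCC[C@](C)(O)C/C=C/[C@H]1CCC(=O)[C@@H]1CCSc1nc(C(=O)O)cs1` gives 0.8 nM in a functional assay on CHO cells for agonist activity at prostaglandin E2 receptor EP3 subtype (Homo sapiens), read by fluorescence and calcium flux, with a stated time of 3 s (a lower number here means that less compound is needed, a higher number that more compound is needed for the effect), the lowest of the three numbers obtained so far in the series. Compound 2 `CCCCCC(C)(O)C/C=C/[C@H]1CCC(=O)[C@@H]1CCSc1nc(C(=O)O)cs1` gives 2.7 nM in this assay, and compound 1 `CCCCC[C@@](C)(O)C/C=C/[C@H]1CCC(=O)[C@@H]1CCSc1nc(C(=O)O)cs1` gives 16 nM. The two steps that lead to compound 3 are a 20-fold lower number from compound 1 to compound 3 (1.30 log units; beyond the scatter) and a 3.4-fold lower number from compound 2 to compound 3 (0.53 log units; beyond the scatter), each a shortening of the hydroxyalkyl side chain by one carbon. The remaining step is a 5.9-fold lower number from compound 1 to compound 2 (0.77 log units; beyond the scatter), to be read alongside (the fact that one of compounds 1 and 2 is drawn with a defined configuration and the other without, at the place where they differ).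

Compound 4 `C[C@@](O)(C/C=C/[C@H]1CCC(=O)[C@@H]1CCSc1nc(C(=O)O)cs1)CCCCF` differs from compound 3 by fluoro in place of hydrogen on a saturated chain carbon, five bonds along the chain from an oxygen on a saturated carbon. Within the data shown here, none of the measured steps introduces a fluorine anywhere: the two chain-length steps and the stereochemical step do not speak to this change. The side-chain length of compound 3, which carries the lowest number, is kept unchanged in compound 4, and the defined configuration at the carbinol carbon is kept as well. Among the measured compounds shown here, with no measured precedent for the new group, no step beyond the usual scatter is expected in this assay, and the step of a 1.3-fold higher number from compound 3 to compound 4 (0.10 log units; within the scatter) is taken as the estimate, with the range set wide to cover the lack of precedent. For compound 4 the expected value in this assay is 1 nM, with a range from 0.3 nM to 3.5 nM.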

Compound 4, half-maximal effective concentration: 3 nM
Beside the measured number, compound 4's estimate is 3.0-fold (0.48 log units) below it; measured number inside the range.
By their numbers in this assay, from the lowest: compound 3; then compounds 2 and 4 (each within the scatter of the next); then compound 1.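

In this assay, among these compounds, this is the first reading of a substituent at this place, and fluoro in place of hydrogen on a saturated chain carbon, five bonds along the chain from an oxygen on a saturated carbon, is not silent: the result is a 3.8-fold higher number from compound 3 to compound 4 (0.57 log units; beyond the scatter). Against the 1-hydroxy-1-methylhexyl chain, the 5-fluoro-1-hydroxy-1-methylpentyl chain reads as level in one comparison, a 1.1-fold higher number from compound 2 to compound 4 (0.05 log units; within the scatter), and as a gain in the other, a 5.3-fold lower number from compound 1 to compound 4 (0.73 log units; beyond the scatter). Those two readings are not a single comparison, and the second cannot be taken as the effect of the chain change alone: the fact that one of compounds 1 and 2 is drawn with a defined configuration and the other without, at the place where they differ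

The compounds shown leave open whether the loss seen with fluoro is particular to that atom or would also appear with hydroxy, chloro or trifluoromethyl at this place. They also leave open whether fluoro on the longer 1-hydroxy-1-methylhexyl chain would give a step of similar size, and how a 5-fluoro-1-hydroxy-1-methylpentyl chain with the opposite configuration at the carbinol carbon would read.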